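Aryl replacement on the shared core: compound 3 to compound 4

The source may report more compounds than this note shows. Statements on the series, on what has been measured and on what is new or still open speak of the compounds shown alone.

Values in a functional assay on ECa-109 cells (Homo sapiens) for cytotoxicity, read by MTT assay, with a stated time of 72 h; on this read-out lower numbers stand for stronger inhibition and higher numbers for weaker inhibition:
- compound 1 `COc1ccc(C=C2C(=O)N(c3ccc(Cl)cc3)N(c3ccc(Cl)cc3)C2=O)cc1` gives > 128000 nM, which is a limit of the assay
- compound 2 `O=C1C(=Cc2cccc(Cl)c2)C(=O)N(c2ccc(Cl)cc2)N1c1ccc(Cl)cc1` gives 22600 nM
- compound 3 `COc1cccc(C=C2C(=O)N(c3ccc(Cl)cc3)N(c3ccc(Cl)cc3)C2=O)c1` gives 29000 nM

Only compound 2 and compound 3 have numerical values, and these two stand level: a 1.3-fold higher number from compound 2 to compound 3 (0.11 log units; within the scatter). The next change leads to compound 4 `O=C1C(=Cc2ccc(F)cc2F)C(=O)N(c2ccc(Cl)cc2)N1c1ccc(Cl)cc1`, which has 2,4-difluorophenyl in place of 3-methoxyphenyl on a double-bonded chain carbon bound to a double-bonded ring carbon.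

Two measured steps change the aryl group at this same place, and both lie beyond the scatter: an at least 5.6-fold lower number from compound 1 to compound 2 (0.75 log units; beyond the scatter) and an at least 4.4-fold lower number from compound 1 to compound 3 (0.64 log units; beyond the scatter). Both start from the limit of compound 1, so their true sizes are not known. Among the compounds with values here, neither step involves 2,4-difluorophenyl, and no measured compound carries fluorine. The closest guide is the agreement of compound 2 and compound 3, whose different aryl groups give no separable values in this assay. On that basis, no step beyond the scatter is expected, although a higher number remains possible given the result for compound 1 at > 128000 nM, a limit.

The expected step is a 1.0-fold higher number from compound 3 to compound 4 (0.01 log units; within the scatter).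

For compound 4 the estimated value is 30000 nM, with an expected range from 10000 nM to 100000 nM.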

Compound 4, half-maximal inhibitory concentration: 13100 nM
Beside the measured number, compound 4's estimate is 2.3-fold (0.36 log units) above it, within the range that was stated.
By their numbers in this assay, from the lowest: compounds 4, 2 and 3 (each within the scatter of the next, the first and the last beyond it). At a limit, above all of these: compound 1.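

In this assay, this position now yields a step beyond the scatter between two compounds with numerical values: a 2.2-fold lower number from compound 3 to compound 4 (0.35 log units; beyond the scatter), whereas the earlier numerical pair, compound 2 and compound 3, could not be separated. The change from 3-chlorophenyl to 2,4-difluorophenyl gives no such separation, with a 1.7-fold lower number from compound 2 to compound 4 (0.24 log units; within the scatter), so compound 4 and compound 2 stand level and the aryl change resolves only against compound 3. Compound 1 stands at a limit, and an at least 9.7-fold lower number from compound 1 to compound 4 (0.98 log units; beyond the scatter) therefore sets only a lower bound on the size of that step: the limit of > 128000 nM in this assay, at which 1 of the 4 values shown sits.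

Within the data shown here, still open is whether a phenyl ring carrying a single fluorine would stand with compound 4 or with compound 3, since the one fluorinated example changes two ring positions at once relative to an unsubstituted phenyl. Also open, going by these compounds, is how an amine or a carboxylic acid on the aryl group at this place would read in this assay, and whether any change elsewhere on the shared core would move the numbers further than these aryl replacements.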